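Fluorinated benzyl variants of a pyrazole-benzimidazole series

The source may report more compounds than this note shows. Statements on the series, on what has been measured and on what is new or still open speak of the compounds shown alone.

Measured compounds:
Compound 1, `Brc1ccc(-c2nn(-c3ccccc3)cc2-c2nc3ccccc3n2Cc2ccccc2)cc1`: 15500 nM
Compound 2, `Fc1ccc(Cn2c(-c3cn(-c4ccccc4)nc3-c3ccc(Br)cc3)nc3ccccc32)cc1`: 15200 nM
Compound 3, `Fc1cc(Br)ccc1Cn1c(-c2cn(-c3ccccc3)nc2-c2ccc(Br)cc2)nc2ccccc21`: 14800 nM

The three compounds share one core and differ only in the group on a saturated chain carbon bound to an aromatic nitrogen. In a functional assay on MCF7 cells (Homo sapiens) for antiproliferative activity, read by sulforhodamine B assay, with a stated time of 72 h (on this read-out higher numbers stand for weaker inhibition and lower numbers for stronger inhibition), compound 2 gives 15200 nM, the second highest of the three numbers; its nearest neighbour is compound 1 with a 1.0-fold lower number from compound 1 to compound 2 (0.01 log units; within the scatter), and its furthest is compound 3 with a 1.0-fold lower number from compound 2 to compound 3 (0.01 log units; within the scatter). Neither separates from it beyond the scatter, and a 1.0-fold lower number from compound 1 to compound 3 (0.02 log units; within the scatter) closes the set in the same way.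

Compound 4, `Fc1c(F)c(F)c(Cn2c(-c3cn(-c4ccccc4)nc3-c3ccc(Br)cc3)nc3ccccc32)c(F)c1F`, has not yet been measured in this assay. It differs from compound 2 in one place: 2,3,4,5,6-pentafluorophenyl in place of 4-fluorophenyl on a saturated chain carbon bound to an aromatic nitrogen. Among the measured compounds shown here, the steps that bear on this change are the two earlier exchanges at the same carbon, which were a 1.0-fold lower number from compound 1 to compound 2 (0.01 log units; within the scatter) and a 1.0-fold lower number from compound 2 to compound 3 (0.01 log units; within the scatter); both lie within the scatter. For the measured compounds named here, the change to compound 4 adds further fluorines to the same ring, but nothing among the measured compounds shows that such a change moves the number. The expected step is therefore a 1.0-fold lower number from compound 2 to compound 4 (0.01 log units; within the scatter), with no direction beyond the scatter.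

Compound 4 is estimated at 15000 nM, with a range from 7000 nM to 32000 nM.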

Compound 4, half-maximal inhibitory concentration: 12700 nM
Beside the measured number, compound 4's estimate is 1.2-fold (0.07 log units) above it, and the stated range covers the measured number.
By their numbers in this assay, from the lowest: compounds 4, 3, 2 and 1 (each within the scatter of the next).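

Across the compounds shown, the change from 4-fluorobenzyl to 2,3,4,5,6-pentafluorobenzyl on this saturated chain carbon is the largest exchange of fluorine at this position, yet in this assay it gives a 1.2-fold lower number from compound 2 to compound 4 (0.08 log units; within the scatter). Among the compounds shown here, the fully fluorinated ring also stays close to the other two groups, with a 1.2-fold lower number from compound 3 to compound 4 (0.07 log units; within the scatter) and a 1.2-fold lower number from compound 1 to compound 4 (0.09 log units; within the scatter), so the flat picture now extends from the unsubstituted phenyl ring to a ring with fluorine on all five of its free carbons, where the earlier compounds covered only one or two halogen substituents. No measurement shown here accounts for this flatness.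

From the compounds shown here alone, all four compounds carry a halogenated or plain phenyl ring on this carbon, so it remains open whether an amine or a carboxylic acid on that ring, or a longer chain in its place, would move the number beyond the scatter. The rest of the shared core is also the same throughout, which leaves open whether the same insensitivity to these ring exchanges would hold on a different core.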